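Swapping a hydrazine group for methylsulfanyl on a pyrimidinone core

This account rests on a few compounds, and the source may have more. Where it says the series, first, only, none or still open, it means among the compounds named here.

Measured compounds:
Compound 1, `CSc1nc(-c2ccco2)c(C#N)c(=O)n1C`: 79 ug/mL
Compound 2, `Cn1c(NN)nc(-c2cccc(O)c2O)c(C#N)c1=O`: 29 ug/mL
Compound 3, `Cn1c(NN)nc(-c2ccco2)c(C#N)c1=O`: 58 ug/mL

Compound 1 and compound 3 share a core and differ only by methylsulfanyl in place of aminoamino on an aromatic carbon. In a functional assay, with a stated time of 10 min (on this read-out lower numbers stand for stronger inhibition and higher numbers for weaker inhibition), this change gave a 1.4-fold higher number from compound 3 to compound 1 (0.13 log units; within the scatter). The difference between the core of compound 2 and the core of compound 3 is not broken down here. Compound 4, `CSc1nc(-c2cccc(O)c2O)c(C#N)c(=O)n1C`, is not yet measured; it differs from compound 2 by methylsulfanyl in place of aminoamino on an aromatic carbon. This is the same kind of change as that from compound 3 to compound 1, though the surroundings are not identical: in compound 2 the place is meta to a group of 8 heavy atoms, whereas in compound 3 it is meta to a furan-2-yl group. For compound 4 a step of a 1.4-fold higher number from compound 2 to compound 4 (0.14 log units; within the scatter) in this assay is expected, resting on the step from compound 3 to compound 1, which was a 1.4-fold higher number from compound 3 to compound 1 (0.13 log units; within the scatter), and on the value of compound 2, 29 ug/mL. Compound 4 is therefore estimated at 40 ug/mL, between 20 ug/mL and 80 ug/mL.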

Compound 4, half-maximal inhibitory concentration: 37 ug/mL
Compound 4: the middle estimate sits 1.1-fold (0.03 log units) above what was measured; measured number inside the range.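

Putting methylsulfanyl in place of aminoamino on the core of compound 2 gave a 1.3-fold higher number from compound 2 to compound 4 (0.11 log units; within the scatter) in this assay. Set beside the earlier pair, the change carries over from one core to the other: the same change on two cores in this assay, a 1.4-fold higher number (0.13 log units; within the scatter) from compound 3 to compound 1 and a 1.3-fold higher number (0.11 log units; within the scatter) from compound 2 to compound 4, 1.1-fold (0.03 log units) apart, within the scatter of two such steps. Going by these compounds alone, both steps lie within the scatter, so this shows only that the swap moved the number by no more than repeat measurements might on these two cores; it does not show that the same would hold on any other core.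

The compounds shown leave open what a methoxy group or a longer chain would do at this place. They also leave open whether the match survives when the furan-2-yl group or the group of 8 heavy atoms is replaced by something else.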